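This account rests on a few compounds, and the source may have more. Where it says the series, first, only, none or still open, it means among the compounds named here.

Compound 1, `O=C(Nc1ccc(Cl)c(-c2nnc3c(Cl)cccn23)c1)c1ccccn1`, gives 75500 nM in a functional assay on HeLa cells (Homo sapiens) for antiproliferative activity, read by MTT assay, with a stated time of 72 h; on this read-out higher numbers stand for weaker inhibition and lower numbers for stronger inhibition.
Compound 2, `Cc1nc(C(=O)Nc2ccc(Cl)c(-c3nnc4c(Cl)cccn34)c2)cs1`, gives 79800 nM in this assay.
Compound 3, `O=C(Nc1ccc(Cl)c(-c2nnc3c(Cl)cccn23)c1)c1cccc(Cl)c1`, gives only a limit in this assay, > 100000 nM.

Compound 3 therefore has no number of its own in this assay; it sits at the limit of > 100000 nM in this assay, at which 1 of the 3 values shown sits. The two steps that reach it, an at least 1.3-fold higher number from compound 1 to compound 3 (0.12 log units; that floor lies within the scatter) and an at least 1.2-fold higher number from compound 2 to compound 3 (0.09 log units; that floor lies within the scatter), both have floors that lie within the scatter, so the three amide aryl groups tried so far cannot be told apart on this read-out, and the step of a 1.1-fold higher number from compound 1 to compound 2 (0.02 log units; within the scatter) is also within the scatter.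

Compound 4, `CS(=O)(=O)c1ccc(C(=O)Nc2ccc(Cl)c(-c3nnc4c(Cl)cccn34)c2)cc1`, differs from compound 3 by 4-(methylsulfonyl)phenyl in place of 3-chlorophenyl on a carbonyl carbon. The measured steps that bear on this change are those exchanging one aryl group on the carbonyl carbon for another, and none of them moved the number beyond the scatter. The step of a number no higher from compound 3 to compound 4 (the limit leaves the size open) is therefore expected to be no larger than the scatter, in no fixed direction. Compound 4 is estimated at 100000 nM, with a range from 45000 nM to 300000 nM, and it is expected that the assay may again report only a limit.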

Compound 4, half-maximal inhibitory concentration: > 100000 nM
Compound 4 was reported as a limit; the forecaster's own chance of this, stated with the estimate: 55%; the middle value sits exactly at the limit.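

In this assay compound 4 gives only a limit, as compound 3 does, so a second aryl group on a carbonyl carbon whose other neighbour is an amide-type nitrogen ends at the same point of the read-out: the limit of > 100000 nM in this assay, at which 2 of the 4 values shown sit.

Exchanging 3-chlorophenyl for 4-(methylsulfonyl)phenyl adds hydrogen-bond acceptors to this position yet yields no measured number, and the step between these two limits cannot be read. The two readable steps, an at least 1.2-fold higher number from compound 2 to compound 4 (0.09 log units; that floor lies within the scatter) and an at least 1.3-fold higher number from compound 1 to compound 4 (0.12 log units; that floor lies within the scatter), leave all four amide groups indistinguishable on this read-out.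

From the compounds shown here alone, it remains open whether a carboxylic acid or an amine on the carbonyl carbon would give a number clearly apart from these. Also unresolved is how far compound 3 and compound 4 actually lie past their limits.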